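Moving the chlorine around the benzyl ring in a thioether series

The source may hold more compounds than are shown below. What is called first, only, known or untested is meant among the compounds shown, and "the series" means these compounds.

Measured so far:
compound 1 `CC1=C(C(=O)Nc2ccc(Br)cc2)C(c2ccc(Cl)cc2Cl)N=C(SCc2ccc(Cl)cc2)N1` gives 6.7% in a functional assay on the whole organism (artery, strain albino) with Rattus norvegicus as the target, with a stated time of 30 min, at a dose of 10 mg/kg by the oral route; a higher number here means more inhibition at the dose given (going by the name of the read-out), a lower number less inhibition;
compound 2 `COc1ccc(C2N=C(SCc3ccccc3)NC(C)=C2C(=O)Nc2ccc(Br)cc2)cc1` gives 2.6%;
compound 3 `COc1ccc(C2N=C(SCc3ccccc3Cl)NC(C)=C2C(=O)Nc2ccc(Br)cc2)cc1` gives 4.6%.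

Compound 3 stands second of the three numbers in this assay, with compound 2 and compound 1 both within the scatter of it. Compound 4 `COc1ccc(C2N=C(SCc3ccc(Cl)cc3)NC(C)=C2C(=O)Nc2ccc(Br)cc2)cc1` is not yet measured. It differs from compound 3 in one place: 4-chlorophenyl in place of 2-chlorophenyl on a saturated chain carbon bound to a sulfur, so the (2-chlorobenzyl)sulfanyl group becomes a (4-chlorobenzyl)sulfanyl group. Going by the values given here, the only measured step of a single change, a number 2 percentage points higher from compound 2 to compound 3 (within the scatter), did not rise beyond the scatter, and compound 1, which also carries the 4-chlorobenzyl group, sits within the scatter of compound 3. Compound 4 is therefore expected to show no step beyond the scatter, a number 0.4 percentage points higher from compound 3 to compound 4 (within the scatter). The estimate for compound 4 is 5%, between 0% and 14%.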

Compound 4, a percentage reported as inhibition, in the whole organism at one dose (the size of the read-out at that dose, not a potency): 7.2%
Compound 4: the middle estimate sits 2.2 percentage points below what was measured; the range from low to high includes it.
By their numbers in this assay, from the lowest: compounds 2, 3, 1 and 4 (each within the scatter of the next).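

In this assay, 4-chlorophenyl in place of 2-chlorophenyl on a saturated chain carbon bound to a sulfur gives a number 2.6 percentage points higher from compound 3 to compound 4 (within the scatter), so the two chlorine placements are not told apart. Chloro in place of hydrogen on an aromatic carbon gives a number 4.6 percentage points higher from compound 2 to compound 4 (within the scatter), and 4-methoxyphenyl in place of 2,4-dichlorophenyl on a saturated ring carbon gives a number 0.5 percentage points higher from compound 1 to compound 4 (within the scatter), so neither change separates its pair of compounds. Nothing measured here accounts for these numbers.

From the compounds shown here alone, it remains open whether an amine or a carboxylic acid on the benzyl ring would move the number beyond the scatter. The same question stands for a longer chain in place of the benzyl group.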